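Replacing a benzodioxinyl with dimethoxyphenyl: cytotoxicity outlook

The source may report more compounds than this note shows. Statements on the series, on what has been measured and on what is new or still open speak of the compounds shown alone.

Compound 1 `CN(Cc1ccc2c(c1)OCCO2)c1cc(=O)c2cc(C(F)(F)F)cc([N+](=O)[O-])c2s1` and compound 2 `O=c1cc(NCc2ccc3c(c2)OCCO3)sc2c([N+](=O)[O-])cc(C(F)(F)F)cc12` share a core and differ only in a hydrogen in place of methyl on a nitrogen on an aromatic ring. In an ADME assay on Vero cells (Chlorocebus sabaeus) for cytotoxicity, read by MTT assay, with a stated time of 48 h (on this read-out higher numbers stand for weaker inhibition and lower numbers for stronger inhibition), compound 1 gives > 64 ug/mL, which is a limit of the assay rather than a number. In this assay compound 2 likewise gives > 64 ug/mL, again a limit. The step that the two limits leave unreadable from compound 1 to compound 2 cannot be read, since (the limit of > 64 ug/mL in this assay, at which 2 of the 2 values shown sit).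

Compound 3 `COc1ccc(CNc2cc(=O)c3cc(C(F)(F)F)cc([N+](=O)[O-])c3s2)cc1OC` differs from compound 2 by 3,4-dimethoxyphenyl in place of 2,3-dihydro-1,4-benzodioxin-6-yl on a saturated chain carbon bound to a nitrogen on an aromatic ring. Among the measured compounds shown here, no measured step touches this place; the single recorded step is unreadable and concerns a different position, so nothing measured bears directly on the change. For the measured compounds named here, compound 2 stands at the limit, and the one other value shown is also a limit. The step that the limit leaves unreadable from compound 2 to compound 3 is therefore expected to stay within the scatter, with compound 3 remaining at or past the same limit. Compound 3 is estimated at 100 ug/mL, with a range from 50 ug/mL to 200 ug/mL.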

Compound 3, half-maximal inhibitory concentration: > 64 ug/mL
Compound 3: no number, only a limit; the forecaster's own chance of this, stated with the estimate: 85%; the middle value does not contradict the limit.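

No new step can be read for compound 2 and compound 3, since each gives only a limit in this assay: the limit of > 64 ug/mL in this assay, at which 3 of the 3 values shown sit. The compounds shown leave open how far any of them lies from that limit, and whether 3,4-dimethoxyphenyl in place of 2,3-dihydro-1,4-benzodioxin-6-yl changes the read-out at all.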